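The compounds below may be only part of what the source reports. "The series", "measured", "known", "first", "only" and "open" are said of these compounds alone.

Compound 1 `C/C(=C\c1cc(-c2ccc(C)cc2)co1)C(N)=O` was tested in an ADME assay on NIH3T3 cells (Mus musculus) for cytotoxicity, read by CCK-8 assay, with a stated time of 24 h; a lower number here means a stronger inhibitor, a higher number a weaker inhibitor. In this assay compound 1 gives > 50000 nM, which is a limit of the assay and not a number. Compound 2 `C/C(=C\c1cc(-c2ccc(F)cc2)co1)C(N)=O` differs from compound 1 by fluoro in place of methyl on an aromatic carbon. In this assay compound 2 gives > 50000 nM, again only a limit. The step that the two limits leave unreadable from compound 1 to compound 2 cannot be sized because of the limit of > 50000 nM in this assay, at which 3 of the 3 values shown sit. Compound 3 `C/C(=C\c1nc(-c2ccc(C)cc2)cs1)C(N)=O` rests on a different core; the difference between the two cores is not broken down here. In this assay compound 3 gives > 50000 nM, once more a limit. Compound 4 `C/C(=C\c1nc(-c2ccc(F)cc2)cs1)C(N)=O` differs from compound 3 by fluoro in place of methyl on an aromatic carbon, the same change seen from compound 1 to compound 2. The step that the limit leaves unreadable from compound 3 to compound 4 is expected to be no larger than the scatter, because of the limit of > 50000 nM in this assay, at which 3 of the 3 values shown sit. Compound 4 is therefore expected to give 60000 nM, most probably reported as a limit.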

Compound 4, half-maximal inhibitory concentration: > 50000 nM
Compound 4: a limit, no number; the forecaster's own chance of this, stated with the estimate: 85%; the middle value lies beyond the limit too.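

The step from compound 3 to compound 4 cannot be sized, because both values are limits and not numbers: the limit of > 50000 nM in this assay, at which 4 of the 4 values shown sit. With no actual number among the compounds shown, whether fluoro in place of methyl changes cytotoxicity at all remains open.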